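Pendant phenyl: amino to chloro

This account rests on a few compounds, and the source may have more. Where it says the series, first, only, none or still open, it means among the compounds named here.

Two compounds in the series carry a measured value. In a functional assay on HCT-116 cells (Homo sapiens) for cytotoxicity, read by MTT assay, with a stated time of 48 h (a lower number here means a stronger inhibitor, a higher number a weaker inhibitor), compound 1 `Cc1nc2c3ccccc3ccc2c2nc3c(ccc4ccccc43)c(-c3cccc([N+](=O)[O-])c3)c12` gives 13200 nM, and compound 2 `Cc1nc2c3ccccc3ccc2c2nc3c(ccc4ccccc43)c(-c3ccccc3N)c12` gives 4760 nM. Compound 2 has the lower of the two numbers; the step of a 2.8-fold lower number from compound 1 to compound 2 (0.44 log units; beyond the scatter) separates them. Compound 3 `Cc1nc2c3ccccc3ccc2c2nc3c(ccc4ccccc43)c(-c3ccccc3Cl)c12` has not been measured; it differs from compound 2 by chloro in place of amino on an aromatic carbon. Among the measured compounds shown here, no measured step matches this change: the one step in hand, 2-aminophenyl in place of 3-nitrophenyl, bears on compound 3 only as a sign that a single change on the pendant phenyl shifts this assay by a modest amount rather than a large one. For compound 3 a modest step is therefore expected, of uncertain direction, with a 1.4-fold higher number from compound 2 to compound 3 (0.14 log units; within the scatter) leaning toward a somewhat higher number. The estimate for compound 3 is 6500 nM, with a range from 2500 nM to 16000 nM.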

Compound 3, half-maximal inhibitory concentration: 48200 nM
Compound 3: middle estimate off by 7.4-fold (0.87 log units), on the low side; the measured number lies above the stated range.
By their numbers in this assay, from the lowest: compound 2; then compound 1; then compound 3.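

In this assay a single replacement at this place, ortho to a large group, proves able to move the number much further than the earlier modest step suggested: 2-chlorophenyl in place of 2-aminophenyl gives a 10-fold higher number from compound 2 to compound 3 (1.01 log units; beyond the scatter) and is a large step. The comparison with the 3-nitrophenyl compound reads a 3.7-fold higher number from compound 1 to compound 3 (0.56 log units; beyond the scatter) and is modest, so among these three compounds the 2-chlorophenyl group gives the highest number and the 2-aminophenyl group the lowest. Nothing in hand accounts for the size of the amino-to-chloro step.

From the compounds shown here alone, whether the low number of compound 2 is specific to amino remains open, and a 2-hydroxyphenyl or 2-methoxyphenyl group would bear on that. The effect of the group's place on the phenyl also remains unsettled, and a 3-aminophenyl or 2-nitrophenyl group would separate place from group.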